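The source may hold more compounds than are shown below. What is called first, only, known or untested is meant among the compounds shown, and "the series" means these compounds.

In a functional assay on WM 266-4 cells (Homo sapiens) for antiproliferative activity, read by MTT assay, with a stated time of 24 h (a higher number here means a weaker inhibitor of growth, a lower number a stronger inhibitor of growth), three compounds sharing one core have been measured. Compound 3 `c1ccc(N2N=C(c3ccc4c(c3)OCCO4)CC2c2ccc3ccccc3c2)cc1` gives 13900 nM and compound 2 `Fc1ccccc1C1CC(c2ccc3c(c2)OCCO3)=NN1c1ccccc1` gives 9120 nM, which places the two level with each other. Compound 1 `c1ccc(COc2ccc(C3CC(c4ccc5c(c4)OCCO5)=NN3c3ccccc3)cc2)cc1` gives 1130 nM, a clearly lower number than those of the other two. Compound 4 `Clc1ccc(C2CC(c3ccc4c(c3)OCCO4)=NN2c2ccccc2)cc1` keeps the core of compound 3 but carries 4-chlorophenyl in place of naphthalen-2-yl on a saturated ring carbon. Among the compounds with values here, one measured step bears directly on this carbon, namely a 1.5-fold higher number from compound 2 to compound 3 (0.18 log units; within the scatter), where naphthalen-2-yl replaced 2-fluorophenyl. A second aryl group in place of naphthalen-2-yl is therefore not expected to move the number beyond the scatter. The estimated step is a 1.5-fold lower number from compound 3 to compound 4 (0.19 log units; within the scatter). The range is kept wide, since compound 1 at 1130 nM differs from compound 3 at the same carbon and shows that larger moves can occur there. Compound 4 is expected at about 9000 nM, with an estimated range from 3000 nM to 22000 nM.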

Compound 4, concentration for 50% growth inhibition: 38600 nM
Estimate against measurement, compound 4: 4.3-fold (0.63 log units) below; the measured number lies above the stated range.
By their numbers in this assay, from the lowest: compound 1; then compounds 2 and 3 (each within the scatter of the next); then compound 4.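

In this assay, within the data shown here, the group on this saturated ring carbon proves able to move the number beyond the scatter, which the one earlier step there did not show: 4-chlorophenyl in place of naphthalen-2-yl gives a 2.8-fold higher number from compound 3 to compound 4 (0.44 log units; beyond the scatter), and 4-chlorophenyl in place of 2-fluorophenyl gives a 4.2-fold higher number from compound 2 to compound 4 (0.63 log units; beyond the scatter). The largest change comes on an aromatic carbon of that aryl group, where chloro in place of benzyloxy gives a 34-fold higher number from compound 1 to compound 4 (1.53 log units; beyond the scatter). Compound 1 and compound 4 therefore mark the two ends of the series, and they differ only in that one group.

Nothing measured here explains these steps. The compounds shown leave open whether the low number of compound 1 depends on benzyloxy itself or would also appear with a methoxy group, an amine or a carboxylic acid on that aromatic carbon.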